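Swapping a Cyclohexyl for a Hexyloxy Chain

The source may report more compounds than this note shows. Statements on the series, on what has been measured and on what is new or still open speak of the compounds shown alone.

Compound 1 `CCCCCc1ccc(NS(=O)(=O)c2ccc(N3CCNC3=O)cc2)cc1` gives 990 nM in a functional assay on HT-29 cells (Homo sapiens) for antiproliferative activity, read by sulforhodamine B assay, with a stated time of 48 h; on this read-out higher numbers stand for weaker inhibition and lower numbers for stronger inhibition.
Compound 2 `CC(C)Cc1ccc(NS(=O)(=O)c2ccc(N3CCNC3=O)cc2)cc1` gives > 1000 nM in this assay, which is a limit of the assay and not a number.
Compound 3 `O=C1NCCN1c1ccc(S(=O)(=O)Nc2ccc(C3CCCCC3)cc2)cc1` gives > 1000 nM in this assay, again a limit and not a number.

Compound 3 therefore stands at the edge of what this assay reports: its value is one of the two that sit at the limit of > 1000 nM in this assay, at which 2 of the 3 values shown sit, so no exact figure for it is known. The step from compound 1 to compound 3 is a number no lower from compound 1 to compound 3 (the limit leaves the size open), and the step from compound 2 to compound 3 is a step that the two limits leave unreadable from compound 2 to compound 3. Neither step can be given a size, because each ends at a value that is only a limit.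

Compound 4 `CCCCCCOc1ccc(NS(=O)(=O)c2ccc(N3CCNC3=O)cc2)cc1` carries the change (hexyloxy in place of cyclohexyl on an aromatic carbon). Among the compounds with values here, the one numeric anchor is compound 1 with its pentyl group, whose value lies close to the limit; the two compounds measured beside it did not reach a number. A hexyloxy group in place of a cyclohexyl group is expected to leave compound 4 in the same region, with the step that the limit leaves unreadable from compound 3 to compound 4 estimated as small. The value for compound 4 is thus estimated at 1500 nM, within a range of 600 nM to 5000 nM.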

Compound 4, half-maximal inhibitory concentration: > 1000 nM
Compound 4 was reported as a limit (the forecaster's own chance of this, stated with the estimate: 60%); the middle value lies beyond the limit too.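

In this assay compound 4 is reported only as a limit, so the steps that end at it from compound 2 and compound 3 cannot be read, and the change from cyclohexyl to hexyloxy has no size. Within the data shown here, the one step with a direction is a number no lower from compound 1 to compound 4 (the limit leaves the size open), which means that hexyloxy, an open chain carrying an oxygen, gives no number on this aromatic carbon, just as the isobutyl and cyclohexyl groups gave none. Of the groups tried here, only the pentyl of compound 1 gives a number, and the others all end at the same edge of the read-out: the limit of > 1000 nM in this assay, at which 3 of the 4 values shown sit.

On these data alone, how far compound 2, compound 3 and compound 4 lie past that limit stays unknown, so no order among them can be given. Among these compounds, also open is whether a pentyloxy chain, which would set the oxygen into a chain the length of the one in compound 1, or an amine on the same aromatic carbon would give a number in this assay.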